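The source may hold more compounds than are shown below. What is called first, only, known or untested is meant among the compounds shown, and "the series" means these compounds.

Compound 2 `CC1=C(C(=O)OC2CCCC2)C(c2ccco2)NC(=O)N1` was tested in an assay on membranes from HeLa cells for displacement of a labelled ligand from adenosine receptor A3 (Homo sapiens), read by scintillation counting, with a stated time of 180 min, tested at 1 uM (a lower number here means less inhibition, a higher number more inhibition at the concentration tested (going by the name of the read-out)), where compound 2 gives 14%. Compound 1 `CC1=C(C(=O)C2CC2)C(c2ccco2)NC(=O)N1` differs from it by cyclopentyloxy in place of cyclopropyl on a carbonyl carbon, and in this assay compound 1 gives 7%. For the measured compounds named here, the single measured step, a number 7 percentage points higher from compound 1 to compound 2 (within the scatter), stays within the scatter, so compound 2 stands alongside compound 1 rather than apart from it. Compound 3 `CC1=C(C(=O)OCC2CCC2)C(c2ccco2)NC(=O)N1` has not been measured; it differs from compound 2 by cyclobutylmethyl in place of cyclopentyl on an oxygen next to a carbonyl group. The step of a number 7 percentage points higher from compound 1 to compound 2 (within the scatter) bears on this only loosely, since it exchanged cyclopentyloxy for cyclopropyl rather than reshaping the group on the oxygen next to the carbonyl group, yet it was small. With the same atoms merely joined differently, the step of no change at the digits printed from compound 2 to compound 3 (within the scatter) is expected to stay within the scatter. Compound 3 is therefore estimated to give 14%, in a range from 3% to 28%.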

Compound 3, a percentage reported as inhibition, at one concentration (the size of the read-out at that concentration, not a potency): 1%
Estimate against measurement, compound 3: 13 percentage points above; measured number below the stated range.
By their numbers in this assay, from the lowest: compounds 3, 1 and 2 (each within the scatter of the next, the first and the last beyond it).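

At this position, on an oxygen next to a carbonyl group, this assay does distinguish two groups of the same atoms: cyclobutylmethyl in place of cyclopentyl gives a number 13 percentage points lower from compound 2 to compound 3 (beyond the scatter) and so separates two compounds in a way the earlier step did not. Cyclobutylmethoxy in place of cyclopropyl on a carbonyl carbon gives a number 6 percentage points lower from compound 1 to compound 3 (within the scatter) and leaves compound 3 alongside compound 1, so only the pair of compounds 2 and 3 stands apart. Nothing available here accounts for the step between the two groups.

The compounds shown leave open how an open chain such as pentyl, or a chain ending in an amine, would read in place of cyclopentyl on this oxygen. With readings at a single concentration, they also leave the potency of all three compounds open.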